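The source may report more compounds than this note shows. Statements on the series, on what has been measured and on what is new or still open speak of the compounds shown alone.

Working notes on the series, read in an ADME assay on microsomes from liver (Homo sapiens) for metabolic stability, read by LC-MS, using NADPH, with stated times of 5 min and 30 min, tested at 1 uM; on this read-out higher numbers stand for fast clearance and lower numbers for slow clearance. Within the data shown here, compound 1 (`CN(C)Cc1ccc(C(=O)Nc2cnc(NCc3c(F)ccc4c3CCO4)n3cnnc23)cc1`) gives 13 mL.min-1.g-1 and holds the lower of the two numbers measured so far. Compound 2 (`CC(=O)N1CCC(c2cnc(NCc3c(F)ccc4c3CCO4)c3cn[nH]c(=O)c23)CC1`) gives 207 mL.min-1.g-1 and stands above compound 1 by more than the scatter. Compound 3 (`O=C(Nc1cnc(NCc2c(F)ccc3c2CCO3)n2cnnc12)c1cccnc1`) keeps the core of compound 1 and carries pyridin-3-yl in place of 4-((dimethylamino)methyl)phenyl on a carbonyl carbon. Among the measured compounds shown here, no measured pair isolates this change, and compound 2 differs from compound 1 in more than one place. The closest anchor is therefore compound 1 at 13 mL.min-1.g-1 in this assay and the expected step is small, upward if anything, and not beyond the scatter. The estimated move is a step of a 1.5-fold higher number from compound 1 to compound 3 (0.19 log units; within the scatter) of modest size. For compound 3 the estimated value is 20 mL.min-1.g-1 with an expected range of 8 mL.min-1.g-1 to 50 mL.min-1.g-1 in this read-out.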

Compound 3, intrinsic clearance in microsomes: < 3 mL.min-1.g-1
Compound 3: a limit, no number; the forecaster's own chance of this, stated with the estimate: 5%; middle value at least 6.6-fold (0.82 log units) from the limit.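

In this assay, pyridin-3-yl in place of 4-((dimethylamino)methyl)phenyl on a carbonyl carbon gives an at least 4.3-fold lower number from compound 1 to compound 3 (0.63 log units; beyond the scatter); this is the only single-place step shown, and it establishes that a change at this position can move clearance beyond the scatter. Compound 3 reads < 3 mL.min-1.g-1, which is a limit of the assay and not a number. The full size of the step therefore stays unknown because of that limit: the limit of < 3 mL.min-1.g-1 in this assay, at which 1 of the 3 values shown sits.

The change alters the ring and removes the dimethylaminomethyl group in one move, so the compounds shown do not separate the two. Plain phenyl on the same carbonyl carbon would separate them, and it remains open how that group would read in this assay.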